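Nitro in place of methyl at the assay limit

The source may hold more compounds than are shown below. What is called first, only, known or untested is meant among the compounds shown, and "the series" means these compounds.

Working notes on the series, with two measured compounds so far. In a functional assay on A549 cells (Homo sapiens) for inhibition, read by MTT assay, with a stated time of 72 h (on this read-out lower numbers stand for stronger inhibition and higher numbers for weaker inhibition), compound 1 `COc1cc(O)c(CC=C(C)C)c(O)c1C(=O)/C=C/c1ccc([N+](=O)[O-])cc1` gives 31200 nM. Compound 2 `COc1cc(O)cc(O)c1C(=O)/C=C/c1ccc(C)cc1` gives > 50000 nM, and this is a limit of the assay and not a number. Compound 2 therefore has no exact position, and the series stands at the limit of > 50000 nM in this assay, at which 1 of the 2 values shown sits.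

The next compound is compound 3 `COc1cc(O)cc(O)c1C(=O)/C=C/c1ccc([N+](=O)[O-])cc1`, with the change (nitro in place of methyl on an aromatic carbon). This places nitro in place of methyl on an aromatic carbon, para to a large group. Among the compounds with values here, no measured pair shows this change, so any expectation is weakly supported. Within the data shown here, the one guide is that compound 1 also carries nitro and gives 31200 nM. A small shift toward lower numbers is therefore expected in this assay, and a result that again reaches the limit would be no surprise. The expected at least 1.1-fold lower number from compound 2 to compound 3 (0.07 log units; that floor lies within the scatter) is modest and remains uncertain in size. For compound 3 the estimated value is 42000 nM, with an expected range of 20000 nM to 80000 nM.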

Compound 3, half-maximal inhibitory concentration: > 50000 nM
Compound 3: a limit, no number (the forecaster's own chance of this, stated with the estimate: 50%); middle value at least 1.1-fold (0.07 log units) from the limit.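

In this assay compound 3 gives > 50000 nM, which is a limit of the assay and not a number. The step for nitro in place of methyl on an aromatic carbon cannot be read, with both of its ends now at the limit, so this position shows no readable response to the change, and the series stands as follows: the limit of > 50000 nM in this assay, at which 2 of the 3 values shown sit.

Within the data shown here, the one readable step holds nitro constant and changes only the other site: hydrogen in place of 3-methylbut-2-en-1-yl on an aromatic carbon gives an at least 1.6-fold higher number from compound 1 to compound 3 (0.20 log units; that floor lies within the scatter), and the floor of this step lies within the scatter, so it points toward a role for that chain without establishing one.

Open is whether the 3-methylbut-2-en-1-yl chain alone carries the measurable value of compound 1 or needs nitro alongside it, a question the compounds shown cannot settle with methyl and that chain never paired. Also open, on these data alone, is how this assay would read an amine or a carboxylic acid in place of nitro, or a longer chain in place of 3-methylbut-2-en-1-yl.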